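The source may hold more compounds than are shown below. What is called first, only, known or untested is meant among the compounds shown, and "the series" means these compounds.

Measured so far:
- compound 1, `Cc1ccccc1-n1nc(C)c2c1NC(=O)[C@H](C)S[C@@H]2c1ccc(-c2ccoc2)cc1`: 40%
- compound 2, `CCc1ccccc1-n1nc(C)c2c1NC(=O)[C@H](C)S[C@@H]2c1ccc(Oc2ccccc2)cc1`: 190%
- compound 3, `COc1ccc(Oc2ccc([C@H]3S[C@@H](C)C(=O)Nc4c3c(C)nn4-c3ccccc3C)cc2)cc1`: 70%

In an assay on isolated protein for agonist activity at Bile acid receptor (Homo sapiens), read by AlphaScreen, with a stated time of 30 min (a lower number here means a smaller maximal response, a higher number a larger maximal response), compound 2 gives the highest of the three numbers; compound 3 lies below it by a margin beyond the scatter, and compound 1 lies lower still, also beyond the scatter. Within the data shown here, the only single-point step among the measured compounds is a number 30 percentage points higher from compound 1 to compound 3 (beyond the scatter), which concerns the group on the aromatic carbon and not the aryl group on the ring nitrogen.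

Compound 4, `Cc1cccc(-n2nc(C)c3c2NC(=O)[C@H](C)S[C@@H]3c2ccc(Oc3ccccc3)cc2)c1`, differs from compound 2 by one change: 3-methylphenyl in place of 2-ethylphenyl on an aromatic nitrogen. Among the measured compounds shown here, no measured pair isolates this change. Compound 2 and compound 3 differ in two places at once, so the gap between their values cannot be divided between the two changes. The aryl group on the ring nitrogen is therefore untested on its own, and the direction of the step is open. Given that compound 2 stands far above the other two, a fall back toward the other values is the more likely outcome, but with wide uncertainty. Compound 4 is expected to give 110%, with a range of 40% to 200%, which means an estimated step of a number 80 percentage points lower from compound 2 to compound 4 (beyond the scatter).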

Compound 4, largest response reached (reported as efficacy), in percent of the reference or control that the assay uses: 22%
Compound 4: middle estimate off by 88 percentage points, on the high side; measured number below the stated range.
By their numbers in this assay, from the lowest: compound 4; then compound 1; then compound 3; then compound 2.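

In this assay, the aryl group on the ring nitrogen now has a reading of its own: with 3-methylphenyl in place of 2-ethylphenyl, the result is a number 168 percentage points lower from compound 2 to compound 4 (beyond the scatter). Among these compounds, this group on the aromatic nitrogen therefore has a strong bearing on the maximal response within this pair, and the step exceeds the only earlier single-place step, a number 30 percentage points higher from compound 1 to compound 3 (beyond the scatter), which concerns the group on the aromatic carbon. Nothing available explains why the step is so large.

This change alters both the chain, from ethyl to methyl, and its place on the phenyl ring, so the compounds shown do not tell which of the two carries the step, and the other pairs differ in more than one place and cannot be read; a 3-ethylphenyl group or an unsubstituted phenyl on the same nitrogen, with the phenoxy group of compound 2 kept, would separate these contributions. Also open, going by these compounds, is whether a more distinct group at this position, such as a pyridyl ring or a phenyl bearing a carboxylic acid, would keep any of the response seen for compound 2.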